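Aryl exchange on the ring nitrogen of the shared core

The compounds below may be only part of what the source reports. "The series", "measured", "known", "first", "only" and "open" are said of these compounds alone.

Measured so far:
compound 1, `Nc1scc(CN2CCN(c3cccc(C(F)(F)F)c3)CC2)c1C(=O)c1ccc(Cl)cc1`: -80%
compound 2, `Nc1scc(CN2CCN(c3ccc(F)cc3F)CC2)c1C(=O)c1ccc(Cl)cc1`: -82%

In a functional assay on CHO cells with adenosine receptor A1 (Homo sapiens) as the target, read by cAMP accumulation and immunoassay, with a stated time of 6 min, tested at 10 uM (a higher number here means a weaker effect of the compound at the concentration tested, a lower number a stronger effect), compound 2 gives the lowest of the two numbers shown, with compound 1 nearest. For the measured compounds named here, the single measured step, a number 2 percentage points lower from compound 1 to compound 2 (within the scatter), lies within the scatter. Compound 3, `Nc1scc(CN2CCN(c3ccc(F)c(Cl)c3)CC2)c1C(=O)c1ccc(Cl)cc1`, differs from compound 2 by 3-chloro-4-fluorophenyl in place of 2,4-difluorophenyl on an amine nitrogen in a ring. That step, like the measured one, exchanges only the aryl group on the amine nitrogen in the six-membered non-aromatic ring with two nitrogens, so the expected step of a number 2 percentage points higher from compound 2 to compound 3 (within the scatter) is none beyond the scatter. Compound 3 is therefore estimated at -80% in this assay. The expected range for compound 3 runs from -92% to -65%.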

Compound 3, a percentage reported as activity, at one concentration (the size of the read-out at that concentration, not a potency): -78%
The estimate for compound 3 lay 2 percentage points below the measured number; the measured number falls inside the stated range.
By their numbers in this assay, from the lowest: compounds 2, 1 and 3 (each within the scatter of the next).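

With a number 4 percentage points higher from compound 2 to compound 3 (within the scatter) and a number 2 percentage points higher from compound 1 to compound 3 (within the scatter) in this assay, 3-chloro-4-fluorophenyl cannot be told apart from either 2,4-difluorophenyl or 3-(trifluoromethyl)phenyl on this amine nitrogen. A chlorine-bearing aryl group therefore adds a third halogen-bearing aryl group to the set without a step beyond the scatter. Nothing available explains this flat read-out.

The read-out at one concentration leaves any potency differences among the three compounds open. Also open, as far as these compounds go, is whether the flat read-out would hold with an unsubstituted phenyl, a methoxyphenyl, a pyridine ring or a benzyl group on this nitrogen.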